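Adding an Isopropoxy Group to the Benzyl of Compound 3

A few compounds are considered here, and "the series" means these few. Any claim that something is new, unique, unknown or untested is made for them only; others in the source may bear on it.

Measured compounds:
- compound 1, `O=C(CCCC1CCN(C(=O)C2CCCCC2)CC1)c1ncco1`: 45 nM
- compound 2, `CC(C)(C)CC(=O)N1CCC(CCCC(=O)c2ncco2)CC1`: 90 nM
- compound 3, `O=C(CCCC1CCN(Cc2ccccc2)CC1)c1ncco1`: 315 nM

In an assay on isolated protein for inhibition of Fatty-acid amide hydrolase 1 (Homo sapiens) (a lower number here means a stronger inhibitor, a higher number a weaker inhibitor), compound 3 gives the highest number of the three, with a 7.0-fold higher number from compound 1 to compound 3 (0.85 log units; beyond the scatter) and a 3.5-fold higher number from compound 2 to compound 3 (0.54 log units; beyond the scatter). Compound 4, `CC(C)Oc1cccc(CN2CCC(CCCC(=O)c3ncco3)CC2)c1`, keeps the benzyl of compound 3 and carries one change: isopropoxy in place of hydrogen on an aromatic carbon, placed meta to a large group. Going by the values given here, no measured step touches the aromatic ring; the measured steps all alter what sits on the ring nitrogen, so none bears directly on this change. The expectation therefore rests on little, and a wide range is appropriate. For compound 4 a modest step toward a lower number is estimated, a 2.1-fold lower number from compound 3 to compound 4 (0.32 log units; beyond the scatter), giving an expected value of 150 nM with a range from 40 nM to 600 nM.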

Compound 4, half-maximal inhibitory concentration: 5 nM
Compound 4: middle estimate off by 30-fold (1.48 log units), on the high side, outside the stated range (below it).
By their numbers in this assay, from the lowest: compound 4; then compounds 1 and 2 (each within the scatter of the next); then compound 3.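

The earlier compounds shown here changed only what sits on the ring nitrogen, so they said nothing about the aromatic ring of the benzyl. In this assay that ring proves highly responsive: isopropoxy in place of hydrogen, meta to a large group, gives a 63-fold lower number from compound 3 to compound 4 (1.80 log units; beyond the scatter) and places compound 4 lowest of the four. Nothing available explains why this single change has so large an effect.

As far as these compounds go, whether a smaller methoxy, a longer butoxy chain or an amine would do the same on this carbon remains open. So does whether isopropoxy elsewhere on the ring would match it.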